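Trifluoromethyl in place of chloro on the ethyl compound

The source may hold more compounds than are shown below. What is called first, only, known or untested is meant among the compounds shown, and "the series" means these compounds.

Values below come from an ADME assay on the whole organism (strain Balb) for pharmacokinetics, with Mus musculus as the target, at a dose of 10 mg/kg by the intravenous route; a higher number here means more compound in the circulation at the dose given, a lower number less compound in the circulation
- compound 1 `NC(=O)c1cc(-c2ccnc(N)n2)[nH]c1-c1cc(C(F)(F)F)ccc1Cl` gives 17600 nM
- compound 2 `CCc1ccc(Cl)cc1-c1[nH]c(-c2ccnc(N)n2)cc1C(N)=O` gives 4500 nM

Compound 2 holds the lower of the two numbers, beyond the scatter from compound 1. Compound 3 `CCc1ccc(C(F)(F)F)cc1-c1[nH]c(-c2ccnc(N)n2)cc1C(N)=O` differs from compound 2 by trifluoromethyl in place of chloro on an aromatic carbon, para to an ethyl group (trifluoromethyl in place of chloro on an aromatic carbon). For the measured compounds named here, no measured pair shows this change alone, so support is thin. Compound 1, which also carries trifluoromethyl, gives 17600 nM and on that basis a small rise in this assay is expected, possibly not beyond the scatter. The expected step is a 1.4-fold higher number from compound 2 to compound 3 (0.16 log units; within the scatter) on this estimate. For compound 3 the estimated value is 6500 nM (expected range 2200 nM to 17000 nM).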

Compound 3, maximal plasma concentration in the Mus musculus assay: 38900 nM
Estimate against measurement, compound 3: 6.0-fold (0.78 log units) below; measured number above the stated range.
By their numbers in the Mus musculus assay, from the lowest: compound 2; then compound 1; then compound 3.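

In the Mus musculus assay, compound 2 gives 4500 nM and compound 3 gives 38900 nM; trifluoromethyl in place of chloro, para to an ethyl group, gives an 8.6-fold higher number from compound 2 to compound 3 (0.94 log units; beyond the scatter), so this position carries a step beyond the scatter on the ethyl compound. With trifluoromethyl held, ethyl in place of chloro on an aromatic carbon gives a 2.2-fold higher number from compound 1 to compound 3 (0.34 log units; beyond the scatter), a second single change that also raises the number. In a physicochemical assay for solubility, at pH 7 (on this read-out higher numbers stand for higher solubility and lower numbers for lower solubility), the first change gives a 1.1-fold lower number from compound 2 to compound 3 (0.04 log units; within the scatter), which leaves the two compounds level on that read-out, with compound 2 at 200000 nM and compound 3 at 182000 nM.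

Nothing measured here accounts for the rise in circulating compound. From the compounds shown here alone, whether a nitrile at this position would hold the gain remains open.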